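Replacing the carbamoyl group of compound 2

A few compounds are considered here, and "the series" means these few. Any claim that something is new, unique, unknown or untested is made for them only; others in the source may bear on it.

In a functional assay on HCT-116 cells (Homo sapiens) for inhibition, read by colorimetric assay, with a stated time of 3 days (on this read-out lower numbers stand for stronger inhibition and higher numbers for weaker inhibition), compound 1 (`O=C(CCCCCCCNC(=O)c1cc(=O)c(O)co1)Nc1ccccc1`) gives > 100000 nM as a limit and not a number. In this assay compound 2 (`NC(=O)C(=O)NCCCCCCCC(=O)Nc1ccccc1`) gives > 100000 nM as a limit and not a number. The series therefore stands at the limit of > 100000 nM in this assay, at which 2 of the 2 values shown sit, and offers no number to start from. For the measured compounds named here, the one measured step is a step that the two limits leave unreadable from compound 1 to compound 2 and provides no size to carry forward.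

Compound 3 (`O=C(CCCCCCCNC(=O)C(O)(O)C(F)(F)F)Nc1ccccc1`) differs from compound 2 by 2,2,2-trifluoro-1,1-dihydroxyethyl in place of carbamoyl on a carbonyl carbon and carries 2,2,2-trifluoro-1,1-dihydroxyethyl in place of carbamoyl on a carbonyl carbon. Going by the values given here, no measured step covers this change, so the expectation is weakly supported. The step expected in this assay is an at least 2.5-fold lower number from compound 2 to compound 3 (0.39 log units; beyond the scatter) toward stronger inhibition, though another limit remains quite possible. For compound 3 the estimated value is 40000 nM with an expected range from 8000 nM to 150000 nM in this read-out.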

Compound 3, half-maximal inhibitory concentration: 41700 nM
For compound 3 the middle estimate is 1.0-fold (0.02 log units) below the measured one; measured number inside the range.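

For the compounds shown here, at this position, on a carbonyl carbon whose other neighbour is an amide-type nitrogen, compound 3 is the first to give a number and not a limit in this assay. Placing 2,2,2-trifluoro-1,1-dihydroxyethyl on that carbon gives an at least 2.3-fold lower number from compound 2 to compound 3 (0.37 log units; beyond the scatter), and the same group in place of the larger group with the six-membered ring gives an at least 2.3-fold lower number from compound 1 to compound 3 (0.37 log units; beyond the scatter). Both sizes are lower bounds only, since each step starts from a limit and not from a number: the limit of > 100000 nM in this assay, at which 2 of the 3 values shown sit.

From the compounds shown here alone, whether the fluorine atoms are needed stays open, and a plain methyl ketone in this place would address that. Also open, going by these compounds, are whether a hydroxamic acid on this carbonyl carbon gives a lower number than compound 3, and how a shorter or longer chain changes the read-out.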